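This account rests on a few compounds, and the source may have more. Where it says the series, first, only, none or still open, it means among the compounds named here.

Two compounds with a shared core carrying a methyl-substituted seven-membered diamine ring have been measured. Compound 1, `CN1CCCN(CCn2ccc3c(Br)cccc32)CC1`, gives 33% in an assay on HEK293 cells for binding affinity to 5-hydroxytryptamine receptor 7 (Homo sapiens), read by radioligand binding, tested at 1 uM; on this read-out higher numbers stand for more inhibition at the one concentration tested (going by the name of the read-out) and lower numbers for less inhibition. Compound 2, `CN1CCCN(CCn2ccc3ccc(F)cc32)CC1`, gives 60% in this assay and stands highest of the two numbers, with compound 1 the nearest and lower by a gap beyond the scatter of repeated measurements. Compound 3, `CN1CCCN(CCn2ccc3ccc(OCc4ccccc4)cc32)CC1`, has not yet been measured in this assay. It differs from compound 2 in one place: benzyloxy in place of fluoro on an aromatic carbon. Within the data shown here, no measured pair in this set tells how such an exchange moves the read-out, so the direction has to be guessed. A modest decrease is expected for compound 3 relative to compound 2, a step of a number 10 percentage points lower from compound 2 to compound 3 (within the scatter) in this assay. The estimate for compound 3 in this assay is 50%, with a range from 20% to 80%.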

Compound 3, a percentage reported as inhibition, at one concentration (the size of the read-out at that concentration, not a potency): 28%
Beside the measured number, compound 3's estimate is 22 percentage points above it; the range from low to high includes it.
By their numbers in this assay, from the lowest: compounds 3 and 1 (each within the scatter of the next); then compound 2.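

On the aromatic carbon described as meta to a fused ring and para to a fused ring, benzyloxy in place of fluoro gives a step of a number 32 percentage points lower from compound 2 to compound 3 (beyond the scatter) in this assay. Among these compounds, this is the first measured exchange at this position, and it shows that the read-out at the one concentration tested responds to what sits there when a single fluorine gives way to a group of 8 heavy atoms with its own six-membered aromatic ring and a hydrogen-bond acceptor. No measurement at hand explains the drop.

The compounds shown leave open whether the step follows from the oxygen, from the added ring or only from the whole benzyloxy group. They also leave open where a methoxy group or a hydroxyl group at this position would fall.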